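A sulfonyl group exchange on compound 3

The source may report more compounds than this note shows. Statements on the series, on what has been measured and on what is new or still open speak of the compounds shown alone.

Compound 1 `Cc1ccc(S(=O)(=O)Oc2ccccc2/C=C(\C#N)C(=O)Nc2nnc(Cc3ccc(F)cc3)s2)cc1` gives 72%
Compound 2 `N#C/C(=C\c1ccccc1OS(=O)(=O)c1ccccc1[N+](=O)[O-])C(=O)Nc1nnc(Cc2ccc(F)cc2)s1` gives 61%
Compound 3 `Cc1ccc(S(=O)(=O)Oc2ccccc2/C=C(\C#N)C(=O)Nc2nnc(Cc3cccc(F)c3)s2)cc1` gives 56%

All three values come from a functional assay on RS4-11 cells (Homo sapiens) for inhibition, read by CCK-8 assay, with a stated time of 48 h, tested at 20 uM (a lower number here means less inhibition of growth, a higher number more inhibition of growth at the concentration tested), as one small series. Compound 3, at 56% here, lies within the scatter of compound 2, at 61% in the same read-out. The remaining gap is clear (a number 16 percentage points lower from compound 1 to compound 3 (beyond the scatter)).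

Compound 4 `N#C/C(=C\c1ccccc1OS(=O)(=O)c1ccccc1[N+](=O)[O-])C(=O)Nc1nnc(Cc2cccc(F)c2)s1` differs from compound 3 in one place, with 2-nitrophenyl in place of 4-methylphenyl on a sulfonyl sulfur. The same exchange has been measured once, and it gave a modest fall (a number 11 percentage points lower from compound 1 to compound 2 (beyond the scatter)). That step carries 4-fluorophenyl, not 3-fluorophenyl, and no measurement shows whether it transfers unchanged. Within the data shown here, it remains the only direct guide, so a step of similar size and the same direction is expected in this assay (a number 11 percentage points lower from compound 3 to compound 4 (beyond the scatter)).

For compound 4 the estimated value is 45% with an expected range from 32% to 58% in this read-out.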

Compound 4, percent growth inhibition at one concentration: 68%
Estimate against measurement, compound 4: 23 percentage points below; measured number outside the range, above it.
By their numbers in this assay, from the lowest: compounds 3, 2, 4 and 1 (each within the scatter of the next, the first and the last beyond it).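

In this assay, the exchange of 4-methylphenyl for 2-nitrophenyl on the sulfonyl sulfur has no fixed direction: with 3-fluorophenyl on the other side of the molecule it gives a number 12 percentage points higher from compound 3 to compound 4 (beyond the scatter), and the two measured cases disagree: the same change on two cores in this assay, a number 11 percentage points lower (beyond the scatter) from compound 1 to compound 2 and a number 12 percentage points higher (beyond the scatter) from compound 3 to compound 4, 23 percentage points apart, beyond the scatter of two such steps. The fluorine exchange also depends on its partner, since 3-fluorophenyl in place of 4-fluorophenyl gives a number 7 percentage points higher from compound 2 to compound 4 (within the scatter) when 2-nitrophenyl sits on the sulfonyl sulfur, so the clear loss seen with 4-methylphenyl does not recur there: the same change on two cores in this assay, a number 16 percentage points lower (beyond the scatter) from compound 1 to compound 3 and a number 7 percentage points higher (within the scatter) from compound 2 to compound 4, 23 percentage points apart, beyond the scatter of two such steps. Across these four compounds, the two places therefore do not act independently, and a step measured at one cannot simply be carried over to a compound that differs at the other.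

As far as these compounds go, whether this dependence extends to other groups on the sulfonyl sulfur, such as 4-aminophenyl or a plain methyl, remains open. From the compounds shown here alone, it is also open whether it would persist in full concentration-response curves rather than at a single tested concentration.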